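Saturating the Acyl Side Chain of a Cytidine-Type Amide

A few compounds are considered here, and "the series" means these few. Any claim that something is new, unique, unknown or untested is made for them only; others in the source may bear on it.

Compound 1: `CC(C)CCC(=O)Nc1ccn([C@H]2CC[C@H](O)[C@@H](C)O2)c(=O)n1`; in a functional assay on HCT-116 cells (Homo sapiens) for cytotoxicity, read by sulforhodamine B assay, with a stated time of 24 h (a lower number here means a stronger inhibitor, a higher number a weaker inhibitor), compound 1 gives > 20000 nM, which is a limit of the assay rather than a number.
Compound 2: `C/C=C(\C)C(=O)Nc1ccn([C@H]2CC[C@H](O[C@H]3O[C@H](C)[C@@H](N(C)C)[C@H](O)[C@H]3O)[C@@H](C)O2)c(=O)n1`; in this assay compound 2 gives 6450 nM.

Within the data shown here, compound 2 therefore holds the only numeric reading in this assay; the other reading, that of compound 1, is the limit described by the limit of > 20000 nM in this assay, at which 1 of the 2 values shown sits. Compound 3 is `CC(C)CC(=O)Nc1ccn([C@H]2CC[C@H](O[C@H]3O[C@H](C)[C@@H](N(C)C)[C@H](O)[C@H]3O)[C@@H](C)O2)c(=O)n1`. It differs from compound 2 in one place: isobutyl in place of 1-methylprop-1-en-1-yl on a carbonyl carbon. Among the measured compounds shown here, no measured pair differs in exactly this way, so the size of the step cannot be read from the data. The step from compound 2 to compound 3 is expected to be a modest loss of potency, a 2.2-fold higher number from compound 2 to compound 3 (0.34 log units; beyond the scatter), of a size that may not clear the usual scatter. Compound 3 is accordingly estimated at 14000 nM in this assay, with a plausible range from 5000 nM to 40000 nM.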

Compound 3, half-maximal inhibitory concentration: 2140 nM
Compound 3: middle estimate off by 6.5-fold (0.82 log units), on the high side, outside the stated range (below it).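

In this assay, among these compounds, the acyl side chain on the amide nitrogen turns out to be a place where the reading responds to a small edit, which no earlier pair could show. Putting isobutyl in place of 1-methylprop-1-en-1-yl on a carbonyl carbon gives a 3.0-fold lower number from compound 2 to compound 3 (0.48 log units; beyond the scatter) and so moves toward a stronger inhibitor. The change keeps the same number of heavy atoms, all carbon, and removes only the double bond outside the rings, together with the shape of the chain. Nothing measured here explains why this step occurs.

The two compounds compared cannot separate the loss of the double bond from the change in branching, which a straight butyl chain would help to resolve. As far as these compounds go, it also remains open how a longer chain, a phenyl ring or an amine would read at this carbonyl carbon.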